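Swapping the Hydrazone Aryl Group on a Shared Core

This account rests on a few compounds, and the source may have more. Where it says the series, first, only, none or still open, it means among the compounds named here.

Compound 1 `C=CC(=O)Nc1cccc(Nc2nc(N/N=C/c3ccccc3F)ncc2Cl)c1` gives 3500 nM in an ADME assay on HT-29 cells (Homo sapiens) for inhibition, read by MTT assay, with a stated time of 72 h; on this read-out higher numbers stand for weaker inhibition and lower numbers for stronger inhibition.
Compound 2 `C=CC(=O)Nc1cccc(Nc2nc(N/N=C(\C)c3ccc(C)cc3)ncc2Cl)c1` gives 3210 nM in this assay.
Compound 3 `CN(C)C/C=C/C(=O)Nc1cccc(Nc2nc(N/N=C/c3ccccc3F)ncc2Cl)c1` gives 3660 nM in this assay.

Of the three numbers, that of compound 3 is the largest, yet all three sit within the scatter of one another, so none can be called stronger or weaker. Compound 4 `CN(C)C/C=C/C(=O)Nc1cccc(Nc2nc(N/N=C/c3ccncc3)ncc2Cl)c1` differs from compound 3 by one change: pyridin-4-yl in place of 2-fluorophenyl on a carbon with a double bond to nitrogen. Among the measured compounds shown here, two measured steps bear on it. The step of a 1.1-fold lower number from compound 1 to compound 2 (0.04 log units; within the scatter) also swapped the aryl group on that same hydrazone carbon and moved nothing beyond the scatter, and the step of a 1.0-fold higher number from compound 1 to compound 3 (0.02 log units; within the scatter) was likewise flat. The expected step of a 1.0-fold lower number from compound 3 to compound 4 (0.02 log units; within the scatter) is therefore none beyond the scatter. Compound 4 is estimated at 3500 nM, with a range from 1500 nM to 8000 nM.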

Compound 4, half-maximal inhibitory concentration: 25200 nM
Beside the measured number, compound 4's estimate is 7.2-fold (0.86 log units) below it, and the stated range ends below it.
By their numbers in this assay, from the lowest: compounds 2, 1 and 3 (each within the scatter of the next); then compound 4.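

Among the compounds shown here, the carbon with a double bond to nitrogen is not indifferent to its aryl group: in this assay, pyridin-4-yl in place of 2-fluorophenyl gives a 6.9-fold higher number from compound 3 to compound 4 (0.84 log units; beyond the scatter), which means weaker inhibition and is the first step here beyond the scatter. Nothing measured here explains this loss.

The compounds shown leave open whether the departing fluorine or the entering ring nitrogen accounts for the step, and an unsubstituted phenyl group at this carbon would help separate the two. On these data alone, whether pyridin-4-yl does the same alongside the vinyl amide of compound 1 also remains open.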